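This account rests on a few compounds, and the source may have more. Where it says the series, first, only, none or still open, it means among the compounds named here.

Working notes on the series. Compound 1 `COc1cc(C(C)(C)C)ccc1C/N=C(\S)NCc1ccc(NS(C)(=O)=O)cc1` gives 2400 nM in a functional assay for inhibition of Vanilloid receptor (Rattus norvegicus); on this read-out lower numbers stand for stronger inhibition and higher numbers for weaker inhibition. Compound 2 `CCCOc1cc(C(C)(C)C)ccc1C/N=C(\S)NCc1ccc(NS(C)(=O)=O)cc1` gives 250 nM in this assay, and compound 3 `CCCCOc1cc(C(C)(C)C)ccc1C/N=C(\S)NCc1ccc(NS(C)(=O)=O)cc1` gives 60 nM in this assay. Compound 3 thus stands lowest of the three numbers, with a 4.2-fold lower number from compound 2 to compound 3 (0.62 log units; beyond the scatter) and a 40-fold lower number from compound 1 to compound 3 (1.60 log units; beyond the scatter) both beyond the scatter.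

The next member is compound 4 `CCCCCOc1cc(C(C)(C)C)ccc1C/N=C(\S)NCc1ccc(NS(C)(=O)=O)cc1`. Its change from compound 3 is methyl in place of hydrogen on a saturated chain carbon, four bonds along the chain from an oxygen on an aromatic ring. The measured steps that bear on it are the earlier chain extensions on the same oxygen: a 9.6-fold lower number from compound 1 to compound 2 (0.98 log units; beyond the scatter) and a 4.2-fold lower number from compound 2 to compound 3 (0.62 log units; beyond the scatter). Each extension has lowered the number, though the gain has shrunk from the first extension to the second. Among the compounds with values here, no measured compound shows the extension reversing direction, so nothing says where the lowering stops, only that it has been slowing. A further lowering in this assay is therefore expected, smaller than the last one, and the expected step is a 2.4-fold lower number from compound 3 to compound 4 (0.38 log units; beyond the scatter). Compound 4 is estimated at 25 nM in this assay, with a range from 10 nM to 60 nM to allow for the step being anywhere from negligible to as large as the last measured one.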

Compound 4, half-maximal inhibitory concentration: 70 nM
Compound 4: the middle estimate sits 2.8-fold (0.45 log units) below what was measured, and the stated range ends below it.
By their numbers in this assay, from the lowest: compounds 3 and 4 (each within the scatter of the next); then compound 2; then compound 1.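

In this assay, within the data shown here, this is the first extension on the oxygen that gives no readable lowering: the methyl placed four bonds along the chain from an oxygen on an aromatic ring comes with a 1.2-fold higher number from compound 3 to compound 4 (0.07 log units; within the scatter) and leaves compound 3 and compound 4 not distinguishable. The gain over the shorter chains stays in place, with a 3.6-fold lower number from compound 2 to compound 4 (0.55 log units; beyond the scatter) and a 34-fold lower number from compound 1 to compound 4 (1.54 log units; beyond the scatter) both standing beyond the scatter, so the steady lowering seen in the earlier extensions holds only as far as compound 3, and compound 4 goes against any rule that each added carbon lowers the number. Nothing measured in this series gives a reason for the flattening at this chain length.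

Compound 3 and compound 4 alone cannot tell a true plateau from the start of a turn upward, and a longer chain on the same oxygen would be needed to separate the two. Also open, going by these compounds, is how a branched chain of similar size, or a chain ending in a hydroxyl group or an amine, would compare with the unbranched chains at this position in this assay on the shared core.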